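The source may hold more compounds than are shown below. What is called first, only, known or untested is meant among the compounds shown, and "the series" means these compounds.

Compound 2 `OCc1cc(N2CCCC2)ccc1-c1nc2c(s1)C(O)CCC2` gives 17000 nM in a functional assay on MCF-10A cells (Homo sapiens) for cytotoxicity, read by sulforhodamine B assay, with a stated time of 2 days (on this read-out lower numbers stand for stronger inhibition and higher numbers for weaker inhibition), the lowest of the two numbers recorded here. Compound 1 `CN(C)c1ccc(-c2nc3c(s2)C(O)CNC3)cc1` gives 70200 nM in this assay. Compound 3 `OC1CCCc2nc(-c3ccc(N4CCCC4)cc3)sc21` reaches only a limit of this assay, > 100000 nM, which is also recorded as the limit of > 100000 nM in this assay, at which 1 of the 3 values shown sits. The step of an at least 5.8-fold higher number from compound 2 to compound 3 (0.76 log units; beyond the scatter) corresponds to hydrogen in place of hydroxymethyl on an aromatic carbon. Compound 4 `CN(C)c1ccc(-c2nc3c(s2)C(O)CCC3)c(CO)c1` differs from compound 2 by dimethylamino in place of pyrrolidin-1-yl on an aromatic carbon. Within the data shown here, no measured step tracks this exchange directly, and compound 1, which also carries dimethylamino, differs from compound 2 in other places as well. Compound 4 is expected to show a modest rise, a 1.8-fold higher number from compound 2 to compound 4 (0.25 log units; within the scatter), since compound 1 with its dimethylamino gives 70200 nM. The estimate for compound 4 is 30000 nM, between 10000 nM and 90000 nM.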

Compound 4, half-maximal inhibitory concentration: > 100000 nM
Compound 4: only a limit was reported; the forecaster's own chance of this, stated with the estimate: 15%; middle value at least 3.3-fold (0.52 log units) away from the limit.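

Among these compounds, until this result, only the hydroxymethyl group had been tied to a step, but the aromatic carbon carrying pyrrolidin-1-yl also counts in this assay: dimethylamino there gives an at least 5.8-fold higher number from compound 2 to compound 4 (0.76 log units; beyond the scatter). The size of this step is only a bound, as compound 4 stands at a limit of the assay: the limit of > 100000 nM in this assay, at which 2 of the 4 values shown sit.

Among the compounds that differ in one place, the measured number belongs only to compound 2, which carries both pyrrolidin-1-yl and hydroxymethyl. As far as these compounds go, whether piperidin-1-yl, morpholin-4-yl or a plain amine on this aromatic carbon would keep a number in this assay stays open.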